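A few compounds are considered here, and "the series" means these few. Any claim that something is new, unique, unknown or untested is made for them only; others in the source may bear on it.

The measured compounds:
- compound 1 `COc1cccc(-c2c(S(=O)(=O)c3ccc(C)c(C)c3)cnc3cc(F)ccc23)c1`: in an ADME assay on microsomes from liver (Homo sapiens) for metabolic stability, tested at 2.5 uM (on this read-out lower numbers stand for slow clearance and higher numbers for fast clearance), compound 1 gives 8.78 mL/min.
- compound 2 `Cc1ccc(S(=O)(=O)c2cnc3cc(F)ccc3c2-c2cccc(Cl)c2)cc1F`: in this assay compound 2 gives 2.13 mL/min.
- compound 3 `N#Cc1cccc(S(=O)(=O)c2cnc3cc(F)ccc3c2-c2cccc(Cl)c2)c1`: in this assay compound 3 gives 0.99 mL/min.

Compound 3 has the lowest number of the three, with compound 2 nearest and compound 1 furthest away. Compound 4 `Cc1ccc(S(=O)(=O)c2cnc3cc(F)ccc3c2-c2cccc(Cl)c2)cc1C` has not yet been measured; it differs from compound 3 in one place: 3,4-dimethylphenyl in place of 3-cyanophenyl on a sulfonyl sulfur.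

For the measured compounds named here, one measured step bears on this change. Going a 2.2-fold lower number from compound 2 to compound 3 (0.33 log units; beyond the scatter), the 3-cyanophenyl group gave the lower number. Compound 4 moves the other way, from 3-cyanophenyl back to a group without a nitrile, so a rise of modest size is expected for compound 4 in this assay. Compound 1 also carries a 3,4-dimethylphenyl group on the sulfonyl sulfur, though its other ring differs, and its value is the highest shown. The step of a 3.5-fold higher number from compound 3 to compound 4 (0.55 log units; beyond the scatter) is therefore expected. For compound 4 the estimate is 3.5 mL/min, with a range from 1.5 mL/min to 9 mL/min.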

Compound 4, intrinsic clearance in a liver preparation (reported as CLH), per the amount of preparation that the assay uses: 4.01 mL/min
Estimate against measurement, compound 4: 1.1-fold (0.06 log units) below, within the range that was stated.
By their numbers in this assay, from the lowest: compound 3; then compounds 2 and 4 (each within the scatter of the next); then compound 1.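

In this assay, 3,4-dimethylphenyl in place of 3-cyanophenyl on a sulfonyl sulfur gives a 4.1-fold higher number from compound 3 to compound 4 (0.61 log units; beyond the scatter) and so adds a second comparison in which the nitrile-bearing group has the lower number. Methyl in place of fluoro on an aromatic carbon gives a 1.9-fold higher number from compound 2 to compound 4 (0.27 log units; within the scatter) and stays within the scatter, so the two groups without a nitrile cannot be told apart here. Chloro in place of methoxy on an aromatic carbon gives a 2.2-fold lower number from compound 1 to compound 4 (0.34 log units; beyond the scatter) and shows that a change outside the sulfonyl aryl group can also shift this number.

No evidence on the reason for these steps is available. Still open, going by these compounds, is whether a carboxylic acid or an amine on the sulfonyl-bound ring would give a number as low as the 3-cyanophenyl group does.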